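This account rests on a few compounds, and the source may have more. Where it says the series, first, only, none or still open, it means among the compounds named here.

Compound 1 `c1ccc(-c2nc3ccccn3c2NC2CCOC2)nc1`: in an ADME assay on THP-1 cells (Homo sapiens) for cytotoxicity (on this read-out higher numbers stand for lower toxicity in this test and lower numbers for higher toxicity in this test), compound 3 does not apply here; compound 1 reaches only the assay limit > 50000 nM.

Let me restate cleanly.

Compound 1 `c1ccc(-c2nc3ccccn3c2NC2CCOC2)nc1`: in this assay compound 1 gives only the assay limit > 50000 nM.
Compound 2 `COc1ccc(-c2nc3ccc(C)cn3c2NC2CCCC2)cc1OC`: in this assay compound 2 gives only the assay limit > 50000 nM.
Compound 3 `Cc1ccn2c(NC3CCCC3)c(-c3ccc(N(C)C)cc3)nc2c1`: in this assay compound 3 gives only the assay limit > 50000 nM.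

Compound 3 therefore stands nowhere distinct on the numbers shown: every value here is a limit and not a number, and all three sit together at the limit of > 50000 nM in this assay, at which 3 of the 3 values shown sit. No ordering among compound 1, compound 2 and compound 3 can be drawn from this.

Compound 4 `CN(C)c1ccc(-c2nc3ccccn3c2NC2CCCC2)cc1` differs from compound 3 in one place: hydrogen in place of methyl on an aromatic carbon. For the measured compounds named here, no pair of measured compounds shows the effect of such a change, so there is no measured step to lean on. Given that compound 3 sits only at a limit in this assay, the step from compound 3 to compound 4 is expected to stay within the scatter, a step that the limit leaves unreadable from compound 3 to compound 4. Compound 4 is therefore estimated at 60000 nM in this assay, within a range from 25000 nM to 150000 nM, most likely again reported only as a limit.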

Compound 4, half-maximal cytotoxic concentration: > 50000 nM
Compound 4: no number, only a limit (the forecaster's own chance of this, stated with the estimate: 85%); the middle value lies beyond the limit too.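

Compound 3 and compound 4 each give only a limit, not a number, in this assay, so no step between them can be read: the limit of > 50000 nM in this assay, at which 4 of the 4 values shown sit.

The compounds shown leave open how toxic any of them is in this test, and whether hydrogen in place of methyl changes that at all.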